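The source may hold more compounds than are shown below. What is called first, only, known or untested is meant among the compounds shown, and "the series" means these compounds.

In an ADME assay on Vero 76 cells (Chlorocebus sabaeus) for cytotoxicity, read by MTT assay, with a stated time of 96 h (on this read-out higher numbers stand for lower toxicity in this test and lower numbers for higher toxicity in this test), compound 1 `Cc1ccccc1C1CC(c2ccc(OCc3ccccc3)cc2)=NN1c1ccc(S(N)(=O)=O)cc1` gives 100000 nM. Compound 2 `NS(=O)(=O)c1ccc(N2N=C(c3ccc(OCc4ccccc4)cc3)CC2c2ccccc2)cc1` is reported only as a limit, > 100000 nM. Compound 3 `NS(=O)(=O)c1ccc(N2N=C(c3ccc(Oc4ccccc4)cc3)CC2c2ccccc2)cc1` gives 85000 nM, a value within the scatter of that of compound 1, so the numbers for these two cannot be told apart. All three compounds thus sit close to the limit of > 100000 nM in this assay, at which 1 of the 3 values shown sits.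

Compound 4 `NS(=O)(=O)c1ccc(N2N=C(c3ccc(Oc4ccccc4)cc3)CC2c2cccc(Cl)c2)cc1` differs from compound 3 by chloro in place of hydrogen on an aromatic carbon. This is chloro in place of hydrogen on an aromatic carbon, meta to a large group, which turns phenyl into 3-chlorophenyl. Going by the values given here, no measured step adds a chloro group, so the evidence is only indirect. The nearest is a number no lower from compound 1 to compound 2 (the limit leaves the size open), which also exchanges a substituent on an aromatic carbon, though its size cannot be read. The other is an at least 1.1-fold lower number from compound 2 to compound 3 (0.07 log units; that floor lies within the scatter), a change elsewhere in the molecule that shows no shift beyond the scatter. Neither step points to a large effect in this assay, and a report of compound 4 as a limit alone remains possible. The estimate therefore means a 1.2-fold lower number from compound 3 to compound 4 (0.08 log units; within the scatter), with no expected change beyond the scatter. Compound 4 is expected at 70000 nM, with an estimated range from 30000 nM to 100000 nM.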

Compound 4, half-maximal cytotoxic concentration: 88000 nM
For compound 4 the middle estimate is 1.3-fold (0.10 log units) below the measured one; the range from low to high includes it.
By their numbers in this assay, from the lowest: compounds 3, 4 and 1 (each within the scatter of the next).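

In this assay, the exchange gives a 1.0-fold higher number from compound 3 to compound 4 (0.02 log units; within the scatter), so a chloro group on this ring, meta to a large group, yields a number that cannot be told apart from that of compound 3. Going by these compounds alone, this is the first step on this ring that can be read, since the earlier exchange of methyl for hydrogen there, from compound 1 to compound 2, ends in a limit and its size stays open. Turning phenyl into 3-chlorophenyl thus brings no shift beyond the scatter on the phenoxy-bearing compounds, and the series stays near the top of the range read here, with compound 2 alone reported as a limit: the limit of > 100000 nM in this assay, at which 1 of the 4 values shown sits.

What the compounds shown leave open is whether an amine, a carboxylic acid or a longer chain on this ring would give a number set apart from those of compound 3 and compound 4. From the compounds shown here alone, it also remains open whether chloro would behave the same way in the benzyl-bearing compounds, or at another place on the ring, since this single step speaks only for 3-chlorophenyl on the core of compound 3.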